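Chlorine Position on the Sulfonamide Ring of Compound 3

The compounds below may be only part of what the source reports. "The series", "measured", "known", "first", "only" and "open" are said of these compounds alone.

Compound 1 `O=C(/C=C/c1cccc(NC(=O)c2ccccc2Cl)c1)c1nc2ccccc2[nH]1` gives 1280 nM in a functional assay on HCT-116 cells (Homo sapiens) for antiproliferative activity, read by MTT assay, with a stated time of 48 h; on this read-out higher numbers stand for weaker inhibition and lower numbers for stronger inhibition.
Compound 2 `O=C(Nc1cccc(/C=C/C(=O)c2nc3ccccc3[nH]2)c1)c1ccc(Cl)cc1` gives 2270 nM in this assay.
Compound 3 `O=C(/C=C/c1cccc(NS(=O)(=O)c2cccc(Cl)c2)c1)c1nc2ccccc2[nH]1` gives 737 nM in this assay.

Among these three, compound 3 shows the lowest number; one of the two steps that end there is a 1.7-fold lower number from compound 1 to compound 3 (0.24 log units; within the scatter), while the other is a 3.1-fold lower number from compound 2 to compound 3 (0.49 log units; beyond the scatter). Compound 4 `O=C(/C=C/c1cccc(NS(=O)(=O)c2ccc(Cl)cc2)c1)c1nc2ccccc2[nH]1` has not yet been measured. It differs from compound 3 only in 4-chlorophenyl in place of 3-chlorophenyl on a sulfonyl sulfur. Within the data shown here, no measured pair shows this exact shift of the chlorine on a sulfonyl-bearing ring. The closest comparison is the amide pair, where the change of chlorine position gave a 1.8-fold higher number from compound 1 to compound 2 (0.25 log units; within the scatter). On that basis the step in this assay is expected to be small and, if anything, toward a slightly higher number, with a move beyond the scatter considered unlikely. The step from compound 3 to compound 4 is therefore estimated as a 1.3-fold higher number from compound 3 to compound 4 (0.11 log units; within the scatter). Compound 4 is expected to give about 950 nM, within a range from 400 nM to 2200 nM.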

Compound 4, half-maximal inhibitory concentration: 1960 nM
Compound 4: middle estimate off by 2.1-fold (0.31 log units), on the low side, within the range that was stated.
By their numbers in this assay, from the lowest: compounds 3, 1, 4 and 2 (each within the scatter of the next, the first and the last beyond it).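

In this assay, the change from 3-chlorophenyl to 4-chlorophenyl on the sulfonyl sulfur gives a 2.7-fold higher number from compound 3 to compound 4 (0.42 log units; beyond the scatter), the first shift of the chlorine among these compounds to lie beyond the scatter. With 4-chlorophenyl kept in place, exchanging the carbonyl for a sulfonyl gives a 1.2-fold lower number from compound 2 to compound 4 (0.06 log units; within the scatter), so this pair shows no readable effect of that exchange. The other amide comparison, a 1.5-fold higher number from compound 1 to compound 4 (0.19 log units; within the scatter), also stays within the scatter, which means the sulfonyl group does not by itself set compound 4 apart from either amide.

Nothing given here explains why the chlorine's place matters on the sulfonyl-bearing ring. On these data alone, it also remains open how 2-chlorophenyl on the sulfonyl sulfur, or a methoxy or trifluoromethyl group in place of the chlorine, would read.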